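The source may hold more compounds than are shown below. What is called first, only, known or untested is meant among the compounds shown, and "the series" means these compounds.

Measured so far:
compound 1 `O=C(N[C@@H](CO)CN1CCc2cc(F)ccc21)O[C@@H](CC1CCCCC1)C(=O)N1CCOCC1` — 143 nM
compound 2 `C[C@@H](CN1c2ccc(F)cc2CC1(C)C)NC(=O)O[C@@H](CC1CCCCC1)C(=O)N1CCOCC1` — 80 nM
compound 3 `C[C@@H]1CN(C(=O)[C@H](CC2CCCCC2)OC(=O)N[C@@H](C)CN2CC(C)(C)c3cc(F)ccc32)C[C@H](C)O1` — 297 nM

In an assay on isolated protein for inhibition of cathepsin S (Homo sapiens) (a higher number here means a weaker inhibitor, a lower number a stronger inhibitor), compound 3 gives the highest of the three numbers, so it is the weakest inhibitor of this small set. Compound 1 comes nearest to it in this assay, with a number that is still lower by a margin beyond the usual scatter, and compound 2 stands furthest away, with the lowest number of the three. Compounds 1 and 2 carry an unsubstituted morpholine amide, while compound 3 carries a dimethyl-substituted one.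

Compound 4 `C[C@@H](CN1CC(C)(C)c2cc(F)ccc21)NC(=O)O[C@@H](CC1CCCCC1)C(=O)N1CCCCC1` has not yet been measured in this assay. It differs from compound 3 by piperidin-1-yl in place of 2,6-dimethylmorpholin-4-yl on a carbonyl carbon. Among the measured compounds shown here, no pair of measured compounds that differ in only this place is available, so the size of the step cannot be read from the data; given that both compounds with a smaller, unsubstituted ring at this carbonyl return lower numbers than compound 3, a modest step towards a lower number is expected, near the edge of the scatter, as a 2.0-fold lower number from compound 3 to compound 4 (0.30 log units; within the scatter). For compound 4 in this assay the estimate is 150 nM, with a range from 50 nM to 450 nM.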

Compound 4, inhibition constant: 39 nM
Compound 4: the middle estimate sits 3.8-fold (0.59 log units) above what was measured; measured number outside the range, below it.
By their numbers in this assay, from the lowest: compound 4; then compounds 2 and 1 (each within the scatter of the next); then compound 3.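

In this assay, among the compounds shown here, piperidin-1-yl in place of 2,6-dimethylmorpholin-4-yl on a carbonyl carbon gives a 7.6-fold lower number from compound 3 to compound 4 (0.88 log units; beyond the scatter), the first step at this position whose size can be read, and it lies beyond the scatter. It also shows that a ring with no hydrogen-bond acceptor and no defined stereocentres is accepted here, yet the ring oxygen, the methyl groups and the stereocentres all leave in this one step, so their separate shares cannot be told apart. No measurement at hand bears on the reason for the step.

Where a plain morpholin-4-yl on the core of compound 4 would fall remains open, and this would separate the loss of the methyl groups from the loss of the ring oxygen. Also open, from the compounds shown here alone, is how a pyrrolidin-1-yl ring or an open-chain diethylamino group would read at this carbonyl.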